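Urea aryl swap on the shared core

This account rests on a few compounds, and the source may have more. Where it says the series, first, only, none or still open, it means among the compounds named here.

Compound 2 `COc1cc(Cl)cc(-c2nn(-c3cccc(NC(=O)Nc4ccc(Cl)c(Cl)c4)c3)cc2-c2ccncc2)c1` stands highest of the two numbers in a functional assay on IGROV-1 cells (Homo sapiens) for inhibition, read by sulforhodamine B assay, with a stated time of 48 h, tested at 100 uM (a higher number here means a weaker effect of the compound at the concentration tested, a lower number a stronger effect), where compound 2 gives 8%. Its nearest neighbour, compound 1 `COc1cc(Cl)cc(-c2nn(-c3cccc(NC(=O)Nc4cc(C(F)(F)F)cc(C(F)(F)F)c4)c3)cc2-c2ccncc2)c1`, sits lower by a gap beyond the scatter; in this assay compound 1 gives -42%. Within the data shown here, no single-change step between measured compounds is available. Compound 3 `COc1cc(Cl)cc(-c2nn(-c3cccc(NC(=O)Nc4cccc(C(F)(F)F)c4)c3)cc2-c2ccncc2)c1` carries 3-(trifluoromethyl)phenyl in place of 3,4-dichlorophenyl on an amide-type nitrogen on the shared core. A downward step of moderate size is expected, a number 18 percentage points lower from compound 2 to compound 3 (beyond the scatter), because compound 1 gives -42% with a related trifluoromethyl-bearing group. For compound 3 the estimate in this assay is -10%, expected between -45% and 20%.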

Compound 3, a percentage reported as activity, at one concentration (the size of the read-out at that concentration, not a potency): -12%
Compound 3: middle estimate off by 2 percentage points, on the high side; low and high end bracket the measured number.
By their numbers in this assay, from the lowest: compound 1; then compound 3; then compound 2.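

In this assay, hydrogen in place of trifluoromethyl on an aromatic carbon gives a number 30 percentage points higher from compound 1 to compound 3 (beyond the scatter), so a single trifluoromethyl group on this aryl ring changes the read-out. 3-(trifluoromethyl)phenyl in place of 3,4-dichlorophenyl on the amide-type nitrogen gives a number 20 percentage points lower from compound 2 to compound 3 (beyond the scatter), so the read-out at this position also follows which groups the ring carries. No measured property accounts for either step.

Going by these compounds, whether an aryl ring carrying a carboxylic acid or an amine would move the number in this assay remains open. So does the effect of a longer alkyl chain on this nitrogen in place of the aryl ring.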